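A few compounds are considered here, and "the series" means these few. Any claim that something is new, unique, unknown or untested is made for them only; others in the source may bear on it.

The compounds share one core and differ in the rings attached to it. Compound 3, `Oc1ccc(-c2cc(-c3ccccc3OC(F)(F)F)cc(-c3cccc(O)c3)n2)cc1`, is assayed in a functional assay on DU-145 cells (Homo sapiens) for inhibition (a lower number here means a stronger inhibitor, a higher number a weaker inhibitor), where compound 3 gives 7760 nM. This is the higher of the two numbers recorded so far, but its neighbour compound 2, `Oc1ccc(-c2cc(-c3ccccc3OC(F)(F)F)cc(-c3ccccc3O)n2)cc1`, gives 4190 nM, and the step of a 1.9-fold higher number from compound 2 to compound 3 (0.27 log units; within the scatter) does not exceed the scatter, so no order between the two can be claimed. Compound 1, `Oc1ccc(-c2cc(-c3ccccc3C(F)(F)F)cc(-c3ccc(O)cc3)n2)cc1`, carries a trifluoromethyl group rather than a trifluoromethoxy group and in this assay compound 1 reaches only the limit > 50000 nM, which is a limit of the assay and not a number; this is the case described by the limit of > 50000 nM in this assay, at which 1 of the 3 values shown sits.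

Compound 4, `Oc1ccc(-c2cc(-c3ccccc3OC(F)(F)F)cc(-c3ccc(O)cc3)n2)cc1`, is not yet measured. Its change from compound 3 is 4-hydroxyphenyl in place of 3-hydroxyphenyl on an aromatic carbon. For the measured compounds named here, the only measured step touching this part of the molecule, a 1.9-fold higher number from compound 2 to compound 3 (0.27 log units; within the scatter), moved the hydroxyl from one position to another without a change beyond the scatter. On that basis compound 4 is expected to stay close to compound 3, with an estimated step of a 1.3-fold higher number from compound 3 to compound 4 (0.11 log units; within the scatter). Compound 4 is therefore estimated at 10000 nM in this assay, in a range from 3500 nM to 30000 nM.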

Compound 4, half-maximal inhibitory concentration: 16000 nM
Compound 4: middle estimate off by 1.6-fold (0.20 log units), on the low side; the range from low to high includes it.
By their numbers in this assay, from the lowest: compounds 2 and 3 (each within the scatter of the next); then compound 4. At a limit, above all of these: compound 1.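

In this assay, for the compounds shown here, changing 3-hydroxyphenyl to 4-hydroxyphenyl gives a 2.1-fold higher number from compound 3 to compound 4 (0.31 log units; beyond the scatter), so this is the first move of the hydroxyl at this position to exceed the scatter. Changing 2-hydroxyphenyl to 4-hydroxyphenyl points the same way, with a 3.8-fold higher number from compound 2 to compound 4 (0.58 log units; beyond the scatter), and 4-hydroxyphenyl gives the weakest measured inhibition among the three trifluoromethoxy compounds, although the 2-hydroxyphenyl and 3-hydroxyphenyl compounds remain unordered. With 4-hydroxyphenyl held constant, trifluoromethoxy in place of trifluoromethyl now forms a readable pair, giving an at least 3.1-fold lower number from compound 1 to compound 4 (0.49 log units; beyond the scatter), but this step rests on a value for compound 1 that is a limit of the assay and not a number: the limit of > 50000 nM in this assay, at which 1 of the 4 values shown sits.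

On these data alone, it remains open whether a methoxy group or an amine in place of the hydroxyl at this position would give a lower or higher number. The compounds shown also leave open how trifluoromethyl behaves alongside 2-hydroxyphenyl or 3-hydroxyphenyl.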